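Replacing the Amide Substituent of Compound 1

The source may report more compounds than this note shows. Statements on the series, on what has been measured and on what is new or still open speak of the compounds shown alone.

Compound 1 `CCn1c(C(=O)NCC(=O)OC)ccc1C(CC)(CC)c1ccc(OCS(=O)(=O)c2ccccc2)c(C)c1` is tested in a functional assay on BXPC-3 cells (Homo sapiens) for antiproliferative activity, read by MTT assay, with a stated time of 24 h (on this read-out lower numbers stand for stronger inhibition and higher numbers for weaker inhibition), where compound 1 gives 20000 nM, the highest of the two numbers recorded. Compound 3 `CCN(CC)CCNC(=O)c1ccc(C(CC)(CC)c2ccc(OCS(=O)(=O)c3ccccc3)c(C)c2)n1CC` gives 6270 nM in this assay. Compound 2 `CCn1c(C(=O)N[C@@H](CC(=O)OC)C(=O)OC)ccc1C(CC)(CC)c1ccc(OCS(=O)(=O)c2ccccc2)c(C)c1` sits at > 50000 nM in this assay, which is a limit rather than a number. The step of a 3.2-fold lower number from compound 1 to compound 3 (0.50 log units; beyond the scatter) is a modest gain, while an at least 2.5-fold higher number from compound 1 to compound 2 (0.39 log units; beyond the scatter) is a loss that ends at a limit (the limit of > 50000 nM in this assay, at which 1 of the 3 values shown sits). Compound 4 `CCn1c(C(=O)NC2(CO)CC2)ccc1C(CC)(CC)c1ccc(OCS(=O)(=O)c2ccccc2)c(C)c1` differs from compound 1 by 1-(hydroxymethyl)cyclopropyl in place of (methoxycarbonyl)methyl on an amide-type nitrogen. Neither measured step introduces this group, so it is only loosely bracketed by them; a step of no more than modest size, in either direction, is expected. Compound 4 is therefore estimated at 15000 nM, within 5000 nM to 50000 nM, an expected step of a 1.3-fold lower number from compound 1 to compound 4 (0.12 log units; within the scatter).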

Compound 4, half-maximal inhibitory concentration: 45400 nM
Estimate against measurement, compound 4: 3.0-fold (0.48 log units) below, within the range that was stated.
By their numbers in this assay, from the lowest: compound 3; then compound 1; then compound 4. At a limit, above all of these: compound 2.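

In this assay, putting 1-(hydroxymethyl)cyclopropyl in place of (methoxycarbonyl)methyl on the amide-type nitrogen gives a 2.3-fold higher number from compound 1 to compound 4 (0.36 log units; beyond the scatter), so this position responds to the change even though both groups count 5 heavy atoms. Set against the 2-(diethylamino)ethyl group, the same group gives a 7.2-fold higher number from compound 3 to compound 4 (0.86 log units; beyond the scatter), which leaves compound 3 with the lowest number of those with a measured value. Compound 2 stands at a limit: the limit of > 50000 nM in this assay, at which 1 of the 4 values shown sits. Against that limit, the data give an at least 1.1-fold lower number from compound 2 to compound 4 (0.04 log units; that floor lies within the scatter), so no order can be drawn from this step.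

Going by these compounds, whether a carboxylic acid in place of the methyl ester of compound 1 would shift the number stays open. So does the effect of a longer chain carrying the diethylamino group of compound 3.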